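Sulfonamide series: tert-butyl in place of methoxycarbonyl

This account rests on a few compounds, and the source may have more. Where it says the series, first, only, none or still open, it means among the compounds named here.

Measured so far in a functional assay on DLD-1 cells (Homo sapiens) for antiproliferative activity, read by CellTiter-Glo, with a stated time of 72 h; a higher number here means a weaker inhibitor, a lower number a stronger inhibitor:
- compound 1 `CC1CCN(C2CCN(S(=O)(=O)c3ccc(-c4ccccc4)cc3)CC2)CC1` gives 258 nM
- compound 2 `CC1CCN(C2CCN(S(=O)(=O)c3ccc(OCc4ccccc4)cc3)CC2)CC1` gives 385 nM
- compound 3 `COC(=O)c1ccc(S(=O)(=O)N2CCC(N3CCC(C)CC3)CC2)cc1` gives > 5000 nM

For compound 3 the entry in this assay is a limit of the measurement, not a number (the limit of > 5000 nM in this assay, at which 1 of the 3 values shown sits). Compound 1 and compound 2 differ only in the group on the aromatic carbon, and their step of a 1.5-fold higher number from compound 1 to compound 2 (0.17 log units; within the scatter) stays within the scatter. Replacing that group by methoxycarbonyl costs heavily: an at least 19-fold higher number from compound 1 to compound 3 (1.28 log units; beyond the scatter) and an at least 12-fold higher number from compound 2 to compound 3 (1.11 log units; beyond the scatter) both leave compound 3 at the limit.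

Compound 4 `CC1CCN(C2CCN(S(=O)(=O)c3ccc(C(C)(C)C)cc3)CC2)CC1` is not yet measured. It differs from compound 3 by tert-butyl in place of methoxycarbonyl on an aromatic carbon. The two steps that bear on this are the large losses from compound 1 and from compound 2 to compound 3; each of them exchanged a group without carbonyl for methoxycarbonyl. The step to compound 4 runs the other way, back to a group without carbonyl, so a large fall in the number is expected, of the order an at least 8.3-fold lower number from compound 3 to compound 4 (0.92 log units; beyond the scatter), though whether tert-butyl recovers the full level of compound 1 is open. For compound 4 the expected value in this assay is 600 nM, with a range from 150 nM to 3000 nM.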

Compound 4, half-maximal inhibitory concentration: > 5000 nM
Compound 4: no number, only a limit; the forecaster's own chance of this, stated with the estimate: 15%; middle value at least 8.3-fold (0.92 log units) from the limit.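

Compound 4 joins compound 3 at the limit of the measurement in this assay, and its entry is a limit, not a number: the limit of > 5000 nM in this assay, at which 2 of the 4 values shown sit.

The loss at this position is therefore not tied to the carbonyl of methoxycarbonyl, since tert-butyl, with no carbonyl and no hydrogen-bond acceptors, also gives an at least 19-fold higher number from compound 1 to compound 4 (1.28 log units; beyond the scatter) and an at least 12-fold higher number from compound 2 to compound 4 (1.11 log units; beyond the scatter); the step between the two limits cannot be read. Of the four groups shown on this aromatic carbon, only phenyl and benzyloxy, the two that carry a ring of their own, give a measured number, while methoxycarbonyl and tert-butyl, both with no ring and the same count of heavy atoms, give only limits.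

On these data alone, how far compound 3 and compound 4 lie beyond the limit, and whether they differ from each other, stays open. Also open, as far as these compounds go, is whether that second ring must be aromatic, or whether a cyclohexyl group or a longer chain such as hexyl on this carbon would stay at the level of compound 1 and compound 2.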